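Methoxy pattern on the benzamide ring: compound 3

This account rests on a few compounds, and the source may have more. Where it says the series, first, only, none or still open, it means among the compounds named here.

Within the data shown here, the series so far holds two measured compounds sharing one core. Compound 1 `CNc1nc(Nc2ccc(C)c(N)c2)ncc1C(=O)Nc1cc(NC(=O)c2ccccc2OC)ccc1C` carries a 2-methoxyphenyl on the carbonyl carbon; in a functional assay on K562 cells (Homo sapiens) for antiproliferative activity, read by CellTiter-Glo and CCK-8 assay, with a stated time of 72 h (on this read-out lower numbers stand for stronger inhibition of growth and higher numbers for weaker inhibition of growth), compound 1 gives 1980 nM. Compound 2 `CNc1nc(Nc2ccc(C)c(N)c2)ncc1C(=O)Nc1cc(NC(=O)c2ccc(OC)c(OC)c2)ccc1C` carries a 3,4-dimethoxyphenyl in the same position, and in this assay compound 2 gives 380 nM. Among the measured compounds shown here, the step of a 5.2-fold lower number from compound 1 to compound 2 (0.72 log units; beyond the scatter) is the only one available, and it places compound 2 at the lower of the two numbers, with compound 1 the only neighbour.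

Compound 3 `CNc1nc(Nc2ccc(C)c(N)c2)ncc1C(=O)Nc1cc(NC(=O)c2cc(OC)cc(OC)c2)ccc1C` keeps the whole of compound 2 except the substitution pattern of that ring: 3,5-dimethoxyphenyl in place of 3,4-dimethoxyphenyl on a carbonyl carbon. For the measured compounds named here, no measured pair shows a move between two dimethoxy patterns, so the one step available bears on it only loosely: it shows that changing the methoxy placement on this ring can shift the number well beyond the scatter, but not in which direction such a rearrangement goes.

For compound 3 in this assay a small shift toward a higher number is expected, a 1.7-fold higher number from compound 2 to compound 3 (0.23 log units; within the scatter), within a wide range. The estimate for compound 3 is 650 nM, between 200 nM and 2100 nM.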

Compound 3, concentration for 50% growth inhibition: 230 nM
For compound 3 the middle estimate is 2.8-fold (0.45 log units) above the measured one; measured number inside the range.
By their numbers in this assay, from the lowest: compounds 3 and 2 (each within the scatter of the next); then compound 1.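

In this assay, moving the methoxy groups from the 3,4-dimethoxyphenyl to the 3,5-dimethoxyphenyl pattern on a carbonyl carbon stays within the scatter (a 1.7-fold lower number from compound 2 to compound 3 (0.22 log units; within the scatter)), so the two dimethoxy patterns cannot be told apart on this read-out. The 3,5-dimethoxyphenyl group also stands clear of the 2-methoxyphenyl group (an 8.6-fold lower number from compound 1 to compound 3 (0.93 log units; beyond the scatter)), so among these three compounds the low numbers no longer rest on compound 2 alone: both dimethoxyphenyl groups give lower numbers than the 2-methoxyphenyl group, and no compound shown goes against this. Nothing available explains these numbers or connects them to any measured property of the groups.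

The step from the 2-methoxyphenyl group to either dimethoxyphenyl group changes both the count and the placement of the methoxy groups, so the compounds shown cannot separate the two. Also open, on these data alone, is how this position would respond to an unsubstituted phenyl, or to a phenyl carrying an amine or a carboxylic acid in place of the methoxy groups.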